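The compounds below may be only part of what the source reports. "The series", "measured", "known", "first", "only" and "open" are said of these compounds alone.

Compound 1 `Cc1nc(C(NC(=O)C(=O)Nc2ccc(F)cc2F)C2CCCCN2)sc1CCO`: in an ADME assay on TZM-b1 cells (Homo sapiens) for cytotoxicity, read by XTT assay, with a stated time of 3 days (a higher number here means that more compound is tolerated, a lower number that less compound is tolerated), compound 1 gives > 84000 nM, which is a limit of the assay rather than a number.
Compound 2 `Cc1ccc(NC(=O)C(=O)NC(c2nc(C)c(CCO)s2)C2CCCCN2)c(F)c1`: in this assay compound 2 gives > 78800 nM, also a limit.
Compound 3 `Cc1nc(C(NC(=O)C(=O)Nc2ccc(Cl)cc2)C2CCCCN2)sc1CCO`: in this assay compound 3 gives 32800 nM.

Compound 3 is therefore the only one of the three with an actual number; the other two stand at limits. The steps of an at least 2.5-fold lower number from compound 1 to compound 3 (0.40 log units; beyond the scatter) and an at least 2.4-fold lower number from compound 2 to compound 3 (0.38 log units; beyond the scatter) each exchange one substituted phenyl group for another, while a step that the two limits leave unreadable from compound 1 to compound 2 stays unreadable. Compound 4 `Cc1nc(C(NC(=O)C(=O)NC2CCCCCC2)C2CCCCN2)sc1CCO` differs from compound 3 by cycloheptyl in place of 4-chlorophenyl on an amide-type nitrogen. Among the measured compounds shown here, no measured step trades an aromatic ring for a non-aromatic one, so the measured steps bear only loosely on this change. Compound 4 is expected to give a step of a 1.1-fold higher number from compound 3 to compound 4 (0.03 log units; within the scatter) that stays within the scatter. Compound 4 is estimated at 35000 nM, in the range 15000 nM to 90000 nM.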

Compound 4, half-maximal cytotoxic concentration: > 88000 nM
Compound 4: only a limit was reported (the forecaster's own chance of this, stated with the estimate: 30%); middle value at least 2.5-fold (0.40 log units) from the limit.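

In this assay, cycloheptyl on the amide-type nitrogen gives the first non-aromatic ring at this place, with an at least 2.6-fold higher number from compound 3 to compound 4 (0.42 log units; beyond the scatter). Compound 4 reaches only a limit, not a number: the limit of > 88000 nM in this assay, at which 1 of the 4 values shown sits. The steps to compound 4 from compound 1 and from compound 2 join two limits and cannot be read, so among the four compounds only the 4-chlorophenyl of compound 3 gives a number. Still open, as far as these compounds go, is how far compound 4 lies past its limit. Also open, from the compounds shown here alone, is whether cyclohexyl, a hexyl chain or an amine on the cycloheptyl ring would give a number here.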